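Ring-closed amine on the shared core: compound 4

The source may hold more compounds than are shown below. What is called first, only, known or untested is meant among the compounds shown, and "the series" means these compounds.

Measured so far in an assay on cells for displacement of a labelled ligand from corticotropin-releasing factor receptor 1 (Homo sapiens), with a stated time of 100 min; on this read-out lower numbers stand for stronger inhibition and higher numbers for weaker inhibition:
compound 1 `C=C(C)CN(CC)Cc1c(C(F)(F)F)nc2n(-c3c(C)cc(C)cc3C)c(Cl)cn12` gives 67 nM
compound 2 `Cc1cc(C)c(-n2c(Cl)cn3c(CN(CCC(F)(F)F)Cc4cccc(F)c4)c(C(F)(F)F)nc23)c(C)c1` gives 49 nM
compound 3 `CCN(Cc1ccc(Cl)c(Cl)c1)Cc1c(C(F)(F)F)nc2n(-c3c(C)cc(C)cc3C)c(Cl)cn12` gives 580 nM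

Compound 1 stands second highest of the three numbers. Compound 2 sits within the scatter of it, so no order between the two can be claimed; compound 3 lies beyond the scatter and is the weakest of the three. For the measured compounds named here, compound 2 differs from compound 1 in more than one place, so no single step can be drawn from that pair.

Compound 4 `Cc1cc(C)c(-n2c(Cl)cn3c(CN4CCCC4c4ccccc4)c(C(F)(F)F)nc23)c(C)c1` differs from compound 1 by 2-phenylpyrrolidin-1-yl in place of ethyl(2-methylprop-2-en-1-yl)amino on a saturated chain carbon bound to an aromatic carbon. Going by the values given here, the one measured step that bears on this site is an 8.7-fold higher number from compound 1 to compound 3 (0.94 log units; beyond the scatter), in which an aromatic ring arrived on the chain carbon bound to the amine nitrogen and the number rose. In compound 4 an aromatic ring again enters at the amine, now held within a five-membered ring, while the open chain leaves altogether; the effect of the ring closure itself is not covered by any measured pair.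

Weighing the only relevant step, compound 4 is expected to give a weaker number than compound 1, a 3.0-fold higher number from compound 1 to compound 4 (0.47 log units; beyond the scatter), though smaller than the step to compound 3. The change is not the same as in that pair. The estimate for compound 4 is 200 nM, with a range from 60 nM to 700 nM.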

Compound 4, inhibition constant: > 7000 nM
Compound 4 was reported as a limit; the forecaster's own chance of this, stated with the estimate: 3%; at least 35-fold (1.54 log units) between middle value and limit.
By their numbers in this assay, from the lowest: compounds 2 and 1 (each within the scatter of the next); then compound 3. At a limit, above all of these: compound 4.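

In this assay, compound 4 is reported only as a limit: the limit of > 7000 nM in this assay, at which 1 of the 4 values shown sits.

The step of an at least 100-fold higher number from compound 1 to compound 4 (2.01 log units; beyond the scatter) is large, whereas an 8.7-fold higher number from compound 1 to compound 3 (0.94 log units; beyond the scatter) is modest, so this position on a saturated chain carbon bound to an aromatic carbon does not accept every tertiary amine that carries an aromatic ring. Compounds 1, 2 and 3 all keep an open-chain amine and give measured numbers, while compound 4, the only one with its amine closed into a ring, does not.

The compounds shown do not separate the contribution of the five-membered ring from that of its phenyl substituent. A plain pyrrolidin-1-yl group, or an open benzyl(ethyl)amino group with the phenyl ring unsubstituted, would bear on that question.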